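A hydroxy group replaces fluorine in a flat series

A few compounds are considered here, and "the series" means these few. Any claim that something is new, unique, unknown or untested is made for them only; others in the source may bear on it.

Measured in a functional assay on HL-60 cells (Homo sapiens) for cytotoxicity, read by WST assay, with a stated time of 48 h; a lower number here means that less compound is needed, a higher number that more compound is needed for the effect:
compound 1 `Oc1ccccc1C[C@H]1COC[C@@H]1Cc1ccc(Cl)c(Cl)c1`: 34000 nM
compound 2 `Cc1ccccc1C[C@H]1COC[C@@H]1Cc1ccc(Cl)c(Cl)c1`: 21000 nM
compound 3 `Fc1cccc(C[C@H]2COC[C@@H]2Cc2ccc(Cl)c(Cl)c2)c1`: 20000 nM

Compound 3 cannot be separated from the other two on these numbers. The closest pair shows a 1.1-fold lower number from compound 2 to compound 3 (0.02 log units; within the scatter), the widest pair shows a 1.7-fold lower number from compound 1 to compound 3 (0.23 log units; within the scatter), and the remaining pair shows a 1.6-fold lower number from compound 1 to compound 2 (0.21 log units; within the scatter).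

The next compound is compound 4 `Oc1ccc(C[C@H]2COC[C@@H]2Cc2ccc(Cl)c(Cl)c2)cc1`, which keeps the shared core and changes one group, with 4-hydroxyphenyl in place of 3-fluorophenyl on a saturated chain carbon bound to a saturated ring carbon.

All three measured steps bear on this change, and none leaves the scatter. Within the data shown here, the closest precedent is compound 1, which also carries a hydroxy group and gives 34000 nM. Among the measured compounds shown here, no measured compound carries the 4-hydroxyphenyl group itself, so this precedent is only partial. No shift beyond the scatter is expected in this assay, and the estimated step is a 1.3-fold higher number from compound 3 to compound 4 (0.10 log units; within the scatter). For compound 4 the estimated value is 25000 nM, with an expected range of 12000 nM to 50000 nM.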

Compound 4, half-maximal effective concentration: 31000 nM
Compound 4: the middle estimate sits 1.2-fold (0.09 log units) below what was measured; the range from low to high includes it.
By their numbers in this assay, from the lowest: compounds 3, 2, 4 and 1 (each within the scatter of the next).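

On the saturated chain carbon bound to a saturated ring carbon, 4-hydroxyphenyl brings in 1 hydrogen-bond donor and 1 hydrogen-bond acceptor that 3-fluorophenyl does not have, yet this assay shows only a 1.6-fold higher number from compound 3 to compound 4 (0.19 log units; within the scatter) and, against 2-methylphenyl, only a 1.5-fold higher number from compound 2 to compound 4 (0.17 log units; within the scatter). The two hydroxy compounds cannot be told apart either, with a 1.1-fold lower number from compound 1 to compound 4 (0.04 log units; within the scatter), so 4-hydroxyphenyl and 2-hydroxyphenyl read alike here and the series stays flat across all four phenyl groups. Nothing available explains this flatness.

Going by these compounds, whether any group on this carbon can move the number beyond the scatter stays open, for instance an amine or a carboxylic acid in place of these phenyl groups. The shared core is the same in all four compounds, so nothing here tells how much it contributes to the numbers.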